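Hydrazone series: methoxy for hydrogen on the aryl ring

The source may hold more compounds than are shown below. What is called first, only, known or untested is meant among the compounds shown, and "the series" means these compounds.

Measured so far:
compound 1 `CNc1ncccc1C(=O)N/N=C/c1ccccc1` — 22.7%
compound 2 `CNc1ncccc1C(=O)N/N=C/c1ccc(Cl)cc1` — 22.4%

Both measured compounds share the same core and were tested in a functional assay on the whole organism (strain Wistar) for inhibition, with Rattus norvegicus as the target, read by paw edema, with a stated time of 3 h, at a dose of 10 mg/kg by the intraperitoneal route; on this read-out higher numbers stand for more inhibition at the one dose given (going by the name of the read-out) and lower numbers for less inhibition. Going by the values given here, compound 1 stands highest of the two numbers, with compound 2 nearest; the one measured step, a number 0.3 percentage points lower from compound 1 to compound 2 (within the scatter), is within the scatter, so the two values are read as the same.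

The compound still to be measured is compound 3 `CNc1ncccc1C(=O)N/N=C/c1cccc(OC)c1`. Against compound 1 it carries methoxy in place of hydrogen on an aromatic carbon. Among the compounds with values here, no step on this exact change has been measured. Within the data shown here, the only step that bears on it is the exchange of hydrogen for another substituent on the same aromatic ring, the chloro step from compound 1 to compound 2, which gave no change beyond the scatter. On that basis the expected step for methoxy in place of hydrogen on an aromatic carbon is also none beyond the scatter, in either direction.

Compound 3 is therefore estimated at 22% in this assay, with a range of 11% to 33%, meaning an expected step of a number 0.7 percentage points lower from compound 1 to compound 3 (within the scatter).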

Compound 3, a percentage reported as inhibition, in the whole organism at one dose (the size of the read-out at that dose, not a potency): 49.5%
For compound 3 the middle estimate is 27.5 percentage points below the measured one, outside the stated range (above it).
By their numbers in this assay, from the lowest: compounds 2 and 1 (each within the scatter of the next); then compound 3.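

In this assay methoxy in place of hydrogen on the aromatic carbon meta to a large group gives a number 26.8 percentage points higher from compound 1 to compound 3 (beyond the scatter) and so shows that a substituent on this ring can move the read-out at the one dose given. The chloro step gave no such sign, being a number 0.3 percentage points lower from compound 1 to compound 2 (within the scatter) and compound 2 therefore goes against any general reading that replacing hydrogen on this ring raises the number. Nothing available explains the methoxy gain, which rests on a single pair of compounds.

The compounds shown leave open whether the gain belongs to methoxy itself or would also appear with another group at this place, and ethoxy, hydroxy or an amine meta to the same large group would begin to separate these readings. They also leave open whether chloro at this same place would behave like methoxy, and whether the gain holds at other doses or times, since the series is seen here only at a single dose and time.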